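Working notes: the ethenyl ester exchange on compound 3

The source may hold more compounds than are shown below. What is called first, only, known or untested is meant among the compounds shown, and "the series" means these compounds.

Values in a functional assay (aorta) with Rattus norvegicus as the target (a lower number here means that less compound is needed, a higher number that more compound is needed for the effect), for the series:
- compound 1 `COc1ccc(-c2nc(/N=C(\N)N3CCOCC3)sc2-c2ccc(OC)cc2)cc1` gives 66 uM in this series
- compound 2 `COc1ccc(-c2nc(CNC(=O)NC(C)C)sc2-c2ccc(OC)cc2)cc1` gives 5.7 uM in this series
- compound 3 `CCN(CC)C(=O)c1nc(-c2ccc(OC)cc2)c(-c2ccc(OC)cc2)s1` gives 14 uM in this series
- compound 4 `CCOC(=O)/C=C/c1nc(-c2ccc(OC)cc2)c(-c2ccc(OC)cc2)s1` has no value yet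

Compound 3 holds the middle of the three numbers in this assay and lies nearer to compound 2 than to compound 1. Compound 4 carries 2-(ethoxycarbonyl)ethenyl in place of diethylcarbamoyl on an aromatic carbon and keeps the rest of the shared core.

Among the compounds with values here, no measured step covers this exact exchange. The three measured steps all exchange the group at this same carbon. The step of a 12-fold lower number from compound 1 to compound 2 (1.06 log units; beyond the scatter) is large, while a 4.7-fold lower number from compound 1 to compound 3 (0.67 log units; beyond the scatter) and a 2.5-fold higher number from compound 2 to compound 3 (0.39 log units; beyond the scatter) are both modest. The two ringless groups thus differ only modestly, and the entering group also has no ring. Compound 4 is therefore expected to fall near compound 2 and compound 3 rather than near compound 1, though three compounds make thin evidence.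

The estimated step of a 1.2-fold lower number from compound 3 to compound 4 (0.07 log units; within the scatter) is expected to stay within the scatter, with no direction favoured. For compound 4 the estimate is 12 uM with an expected range from 4.5 uM to 35 uM in this assay.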

Compound 4, concentration for half-maximal effect: > 100 uM
Compound 4 ended at the assay's limit; the forecaster's own chance of this, stated with the estimate: 5%; middle value at least 8.3-fold (0.92 log units) from the limit.
By their numbers in this assay, from the lowest: compound 2; then compound 3; then compound 1. At a limit, above all of these: compound 4.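

Notes on the result: in this assay, compound 4 can be read only as a limit and not as a number, and it is alone there among the compounds shown: the limit of > 100 uM in this assay, at which 1 of the 4 values shown sits.

The earlier compounds shown here suggested that ringless groups at this carbon stay close together, but 2-(ethoxycarbonyl)ethenyl breaks that reading, with an at least 7.1-fold higher number from compound 3 to compound 4 (0.85 log units; beyond the scatter) and an at least 17-fold higher number from compound 2 to compound 4 (1.24 log units; beyond the scatter), while the remaining comparison gives an at least 1.5-fold higher number from compound 1 to compound 4 (0.18 log units; that floor lies within the scatter). Having no ring is therefore not enough to keep the number low at this position, and compound 2 and compound 3 do not define what the position accepts. Diethylcarbamoyl and 2-(ethoxycarbonyl)ethenyl each have 7 heavy atoms, so heavy-atom count alone does not set the number here; the exchange replaces the amide nitrogen with an ester oxygen and adds a double bond outside the aromatic ring.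

The step between compound 1 and compound 4 cannot be read, as its floor lies within the scatter. Still open, on these data alone, is whether the rise follows the ester or the ethenyl link; a saturated two-carbon chain bearing the same ester, or a carboxylic acid or diethylamide on the ethenyl link, would separate the two.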